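The compounds below may be only part of what the source reports. "The series", "measured", "known", "first", "only" and "open" are said of these compounds alone.

Working notes on the series. In a functional assay on A-375 cells (Homo sapiens) for antiproliferative activity (a lower number here means a stronger inhibitor, a higher number a weaker inhibitor), compound 3 `O=C(Nc1ccc(-c2ccccc2)cc1)C1CCCN(Cc2ccc(F)c(F)c2)C1` gives 2580 nM and compound 2 `O=C(Nc1ccc(-c2cscn2)cc1)C1CCCN(Cc2ccccc2F)C1` gives 4000 nM, two values within the scatter of each other. Compound 1 `O=C(Nc1ccc(-c2cscn2)cc1)C1CN(Cc2ccc(F)c(F)c2)C1` gives > 20000 nM, which is a limit of the assay and not a number.

Compound 4 `O=C(Nc1ccc(-c2ccoc2)cc1)C1CCCN(Cc2ccc(F)c(F)c2)C1` carries furan-3-yl in place of phenyl on an aromatic carbon, para to a large group: furan-3-yl in place of phenyl on an aromatic carbon. Going by the values given here, no measured pair differs in one place, so the data give no size for this change. No step beyond the scatter is expected in this assay, in either direction. The estimate amounts to a 1.2-fold higher number from compound 3 to compound 4 (0.07 log units; within the scatter), an expected change within the scatter. The expected value for compound 4 is 3000 nM, with an estimated range of 1200 nM to 7500 nM.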

Compound 4, half-maximal inhibitory concentration: 1290 nM
Compound 4: the middle estimate sits 2.3-fold (0.37 log units) above what was measured; measured number inside the range.
By their numbers in this assay, from the lowest: compounds 4, 3 and 2 (each within the scatter of the next, the first and the last beyond it). At a limit, above all of these: compound 1.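

In this assay, going by these compounds alone, furan-3-yl in place of phenyl on an aromatic carbon, para to a large group, gives the first step between compounds that differ in one place: a 2.0-fold lower number from compound 3 to compound 4 (0.30 log units; within the scatter). This position therefore accepts a five-membered aromatic ring with one hetero atom as well as a six-membered aromatic ring of carbon only, with no step beyond the scatter. Nothing measured here accounts for the step.

Going by these compounds, an amine, a carboxylic acid or a longer chain at this position remains open. Also open, on these data alone, is whether the same exchange gives a similar step with another group on the ring nitrogen.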